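Aryl swap on the saturated ring carbon of the pyrazoline series

The source may hold more compounds than are shown below. What is called first, only, known or untested is meant among the compounds shown, and "the series" means these compounds.

Of the compounds shown here, three of the shared core have been measured in an assay on cells for inhibition of histone deacetylase 4 (Homo sapiens), read by fluorescence, with a stated time of 30 min; on this read-out higher numbers stand for weaker inhibition and lower numbers for stronger inhibition. Compound 1 `O=C1NC(=O)/C(=C\c2ccc(OCC(=O)N3N=C(c4ccccc4)CC3c3ccccc3)cc2)S1` gives 1600 nM. Compound 2 `O=C1NC(=O)/C(=C\c2ccc(OCC(=O)N3N=C(c4ccccc4)CC3c3ccc(C(F)(F)F)cc3)cc2)S1` gives 1000 nM. Compound 3 `O=C1NC(=O)/C(=C\c2ccc(OCC(=O)N3N=C(c4ccccc4)CC3c3ccc(Cl)c(Cl)c3)cc2)S1` gives 700 nM, the lowest of the three numbers, separated from compound 1 by a 2.3-fold lower number from compound 1 to compound 3 (0.36 log units; beyond the scatter) but from compound 2 only by a 1.4-fold lower number from compound 2 to compound 3 (0.15 log units; within the scatter). The change to compound 4 `O=C1NC(=O)/C(=C\c2ccc(OCC(=O)N3N=C(c4ccccc4)CC3c3ccc(Br)cc3)cc2)S1` is 4-bromophenyl in place of 3,4-dichlorophenyl on a saturated ring carbon. Among the measured compounds shown here, the steps that bear on it are those at the same saturated ring carbon: a 2.3-fold lower number from compound 1 to compound 3 (0.36 log units; beyond the scatter) and a 1.4-fold lower number from compound 2 to compound 3 (0.15 log units; within the scatter), together with a 1.6-fold lower number from compound 1 to compound 2 (0.20 log units; within the scatter). All of them are small, and a single halogen on the phenyl of compound 4 sits, on structure, between the unsubstituted phenyl of compound 1 and the doubly substituted phenyl of compound 3. The expected step is therefore a 1.3-fold higher number from compound 3 to compound 4 (0.11 log units; within the scatter), a slightly higher number that stays within the scatter. Compound 4 is estimated at 900 nM, with a range from 450 nM to 1800 nM.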

Compound 4, half-maximal inhibitory concentration: 1200 nM
Compound 4: the middle estimate sits 1.3-fold (0.12 log units) below what was measured; the measured number falls inside the stated range.
By their numbers in this assay, from the lowest: compounds 3, 2, 4 and 1 (each within the scatter of the next, the first and the last beyond it).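

On the saturated ring carbon of the five-membered non-aromatic ring, 4-bromophenyl cannot be told apart in this assay from 3,4-dichlorophenyl (a 1.7-fold higher number from compound 3 to compound 4 (0.23 log units; within the scatter)), from 4-(trifluoromethyl)phenyl (a 1.2-fold higher number from compound 2 to compound 4 (0.08 log units; within the scatter)) or from phenyl (a 1.3-fold lower number from compound 1 to compound 4 (0.12 log units; within the scatter)). Among the compounds shown here, compound 4 thus lies within the scatter of both compound 1 and compound 3, the only pair printed as beyond it, so these aryl groups fall into no resolved order at this position. No measurement at hand offers an explanation for these small steps.

On these data alone, whether an amine, a carboxylic acid or a methoxy group on this phenyl would give a step beyond the scatter remains open. Also open, as far as these compounds go, is how a saturated ring such as cyclohexyl or a longer alkyl chain would compare with the aryl groups at this carbon.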